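Swapping the imidazole substituent in a diphenylamide series

The source may report more compounds than this note shows. Statements on the series, on what has been measured and on what is new or still open speak of the compounds shown alone.

Compound 1 `NC(=O)C(CCn1ccnc1)(c1ccccc1)c1ccccc1`; in an assay on ileum with muscarinic acetylcholine receptor M3 (Cavia porcellus) as the target (a higher number here means a weaker inhibitor, a lower number a stronger inhibitor), compound 1 gives 5.07 nM.
Compound 2 `CCc1nccn1CCC(C(N)=O)(c1ccccc1)c1ccccc1`; in this assay compound 2 gives 78.1 nM.
Compound 3 `CC(C)(C)c1nccn1CCC(C(N)=O)(c1ccccc1)c1ccccc1`; in this assay compound 3 gives 30.2 nM.

Compound 3 stands second highest of the three numbers in this assay: compound 1 sits well below it, as a 6.0-fold higher number from compound 1 to compound 3 (0.77 log units; beyond the scatter) shows, while compound 2 sits above it, as a 2.6-fold lower number from compound 2 to compound 3 (0.41 log units; beyond the scatter) shows. Compound 4 `Cc1cn(CCC(C(N)=O)(c2ccccc2)c2ccccc2)cn1` has not been measured. It differs from compound 3 in one place: 4-methyl-1H-imidazol-1-yl in place of 2-(tert-butyl)-1H-imidazol-1-yl on a saturated chain carbon, three bonds along the chain from two aromatic carbons and a carbonyl carbon.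

Two of the measured steps bear on this change. Both additions to the aromatic carbon raised the number: a 15-fold higher number from compound 1 to compound 2 (1.19 log units; beyond the scatter) and a 6.0-fold higher number from compound 1 to compound 3 (0.77 log units; beyond the scatter). Compound 4 removes the tert-butyl from that carbon, which on its own would be expected to bring the number back toward that of compound 1, but it also adds a methyl at a place for which no comparison exists among the three measured compounds. The estimate therefore leans on the return toward compound 1 while leaving room for the new methyl to push the number either way. Compound 4 is expected to give 10 nM in this assay, within 3 nM to 35 nM. This estimate means an expected step of a 3.0-fold lower number from compound 3 to compound 4 (0.48 log units; beyond the scatter).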

Compound 4, antagonist equilibrium constant: 10.1 nM
The estimate for compound 4 lay 1.0-fold (0.00 log units) below the measured number, and the stated range covers the measured number.
By their numbers in this assay, from the lowest: compounds 1 and 4 (each within the scatter of the next); then compound 3; then compound 2.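

In this assay, 4-methyl-1H-imidazol-1-yl is the only substituted group among the compounds shown whose step from the unsubstituted compound 1 stays inside the scatter, with a 2.0-fold higher number from compound 1 to compound 4 (0.30 log units; within the scatter). Replacing the other two substituted groups with it gives a 7.7-fold lower number from compound 2 to compound 4 (0.89 log units; beyond the scatter) for 2-ethyl-1H-imidazol-1-yl and a 3.0-fold lower number from compound 3 to compound 4 (0.48 log units; beyond the scatter) for 2-(tert-butyl)-1H-imidazol-1-yl, so the earlier rise from compound 1 does not follow from any alkyl group on the imidazole. Nothing available for these compounds gives a reason for these differences.

Compound 4 differs from compound 2 and compound 3 both in the alkyl group and in the numbering of the imidazole carbon that bears it, so the steps shown cannot separate the identity of the group from where it sits. Also open, going by these compounds, is how this assay would read with an amine or a carboxylic acid on the imidazole, or with a longer chain on the shared core.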